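Amine end of the propoxy chain: piperidine to piperazine

A few compounds are considered here, and "the series" means these few. Any claim that something is new, unique, unknown or untested is made for them only; others in the source may bear on it.

Compound 2 `COc1cc2c(Oc3ccc(NC(=O)c4nn(-c5ccccc5C)c(=O)cc4C)cc3F)ccnc2cc1OCCCN1CCC(C)CC1` carries a 4-methylpiperidin-1-yl group at the end of the propoxy chain on the shared core. In a functional assay on A549 cells (Homo sapiens) for inhibition, read by MTT assay, with a stated time of 72 h (on this read-out higher numbers stand for weaker inhibition and lower numbers for stronger inhibition), compound 2 gives 1460 nM. For the measured compounds named here, its only neighbour so far is compound 1 `COc1cc2c(Oc3ccc(NC(=O)c4nn(-c5ccccc5C)c(=O)cc4C)cc3F)ccnc2cc1OCCCN1CCCC1`, which in this assay gives 1300 nM; the step of a 1.1-fold higher number from compound 1 to compound 2 (0.05 log units; within the scatter) shows that the two numbers sit within the scatter of each other, so nothing separates them on this read-out.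

Compound 3 `COc1cc2c(Oc3ccc(NC(=O)c4nn(-c5ccccc5C)c(=O)cc4C)cc3F)ccnc2cc1OCCCN1CCN(C)CC1` is the next variation at the same place: 4-methylpiperazin-1-yl in place of 4-methylpiperidin-1-yl on a saturated chain carbon, three bonds along the chain from an oxygen on an aromatic ring. Going by the values given here, the one step that bears on it is the amine exchange from compound 1 to compound 2, which changed the amine at this chain position without moving the number beyond the scatter. Among the compounds with values here, that is the whole of the evidence for what the terminal amine does here; no other compound probes it.

On that basis the step from compound 2 to compound 3 is expected to be a 1.1-fold lower number from compound 2 to compound 3 (0.05 log units; within the scatter), with no shift beyond the scatter in either direction. Compound 3 is therefore estimated at 1300 nM in this assay, within a range of 500 nM to 3500 nM.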

Compound 3, half-maximal inhibitory concentration: 2830 nM
The estimate for compound 3 lay 2.2-fold (0.34 log units) below the measured number; the range from low to high includes it.
By their numbers in this assay, from the lowest: compounds 1, 2 and 3 (each within the scatter of the next, the first and the last beyond it).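

In this assay the amine at the end of the propoxy chain now gives its first separation beyond the scatter, a modest one: 4-methylpiperazin-1-yl in place of pyrrolidin-1-yl gives a 2.2-fold higher number from compound 1 to compound 3 (0.34 log units; beyond the scatter) on the shared core. The direct exchange of 4-methylpiperidin-1-yl for 4-methylpiperazin-1-yl, with a 1.9-fold higher number from compound 2 to compound 3 (0.29 log units; within the scatter), stays within the scatter, so the second ring nitrogen cannot be credited with a separate effect on this read-out, and the three compounds form a graded set in which only the two ends are apart. No measurement at hand accounts for the gap between the pyrrolidin-1-yl and 4-methylpiperazin-1-yl compounds.

On these data alone, it remains open how a morpholin-4-yl group, an unsubstituted piperazin-1-yl group or an open-chain dimethylamino group would read at this chain end, and whether any of them would separate from 4-methylpiperidin-1-yl as well. Also open, as far as these compounds go, is whether the same amine order would hold on an ethoxy or butoxy chain in place of the propoxy chain.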